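This account rests on a few compounds, and the source may have more. Where it says the series, first, only, none or still open, it means among the compounds named here.

Measured so far in a functional assay on PC-12 cells (Rattus norvegicus) for cytotoxicity, read by MTT assay, with stated times of 3 h and 2 h, tested at 50 uM; on this read-out higher numbers stand for a stronger effect at the one concentration tested and lower numbers for a weaker effect:
Compound 1 `O=C(CCCCC1CCSS1)NCc1cn(CCCOc2ccc3cc(-c4ccccc4)c(=O)oc3c2)nn1` gives 23.1%.
Compound 2 `O=C(CCCCC1CCSS1)NCc1cn(CCCOc2ccc3cc(-c4ccc(Br)cc4)c(=O)oc3c2)nn1` gives 74.7%.
Compound 3 `O=C(CCCCC1CCSS1)NCc1cn(CCCCOc2ccc3ccc(=O)oc3c2)nn1` gives 75.8%.

Compound 3 holds the highest number of the three, but compound 2 lies within the scatter of it; only compound 1 stands clearly lower. Compound 4 `O=C(CCCCC1CCSS1)NCc1cn(CCCCOc2ccc3cc(-c4ccc(Cl)c(Cl)c4)c(=O)oc3c2)nn1` differs from compound 3 by 3,4-dichlorophenyl in place of hydrogen on an aromatic carbon. Among the measured compounds shown here, the single measured step, a number 51.6 percentage points higher from compound 1 to compound 2 (beyond the scatter), concerns a different change at a different place and bears only loosely on this one; it shows a large rise where a halogen entered, and compound 3, carrying only hydrogen at the place now altered, already sits high. Nothing measured points to a fall, so the expected step of a number 3.8 percentage points lower from compound 3 to compound 4 (within the scatter) is none beyond the scatter. Compound 4 is estimated at 72%, range 45% to 92%.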

Compound 4, a percentage reported as activity, at one concentration (the size of the read-out at that concentration, not a potency): 69.5%
Compound 4: middle estimate off by 2.5 percentage points, on the high side, within the range that was stated.
By their numbers in this assay, from the lowest: compound 1; then compounds 4, 2 and 3 (each within the scatter of the next).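

In this assay, putting 3,4-dichlorophenyl on the aromatic carbon two atoms from the ring oxygen, where compound 3 carries hydrogen, gives a number 6.3 percentage points lower from compound 3 to compound 4 (within the scatter). This place therefore accepts an added ring of 8 heavy atoms with no change beyond the scatter. Nothing available explains this result.

Going by these compounds, how much of the number for compound 4 belongs to the two chlorines rather than to the phenyl ring itself stays open. So does whether an amine or a carboxylic acid on the added ring would shift the read-out beyond the scatter.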